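Trifluoromethylphenyl replaces methoxyphenyl on a shared core

This account rests on a few compounds, and the source may have more. Where it says the series, first, only, none or still open, it means among the compounds named here.

Measured compounds in a physicochemical assay for lipophilicity, using the shake flask method, in phosphate buffer, measured as octanol-water partition, with a stated time of 85 min, at pH 7.4; on this read-out higher numbers stand for higher lipophilicity and lower numbers for lower lipophilicity:
compound 1, `CCc1ccc(-c2cn3ccnc3c(-c3ccc4ncn(C5CCCCC5)c4c3)n2)cc1`, gives 1.66
compound 2, `CC(=O)c1ccc(-c2cn3ccnc3c(-c3ccc4ncn(C5CCCCC5)c4c3)n2)cc1`, gives 2.06
compound 3, `COc1ccccc1-c1cn2ccnc2c(-c2ccc3ncn(C4CCCCC4)c3c2)n1`, gives 1.72

Compound 3 stands second highest of the three numbers in this assay. Its nearest neighbour is compound 1, with the gap a number 0.06 log units higher from compound 1 to compound 3 (within the scatter), while the gap a number 0.34 log units lower from compound 2 to compound 3 (beyond the scatter) separates it from compound 2, the highest of the three. Within the data shown here, the only pair not involving compound 3 shows the step of a number 0.40 log units higher from compound 1 to compound 2 (beyond the scatter).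

Compound 4, `FC(F)(F)c1cccc(-c2cn3ccnc3c(-c3ccc4ncn(C5CCCCC5)c4c3)n2)c1`, differs from compound 3 in one place: 3-(trifluoromethyl)phenyl in place of 2-methoxyphenyl on an aromatic carbon. Both steps already seen in which the pendant aryl group was exchanged bear on this change. One of them, a number 0.06 log units higher from compound 1 to compound 3 (within the scatter), lay within the scatter; the other, a number 0.34 log units lower from compound 2 to compound 3 (beyond the scatter), was modest and beyond the scatter. Among the measured compounds shown here, no measured step replaces a methoxy group by a trifluoromethyl group, so the direction for compound 4 rests on these two aryl exchanges only, which together make a step of no more than modest size likely in this assay.

Compound 4 is therefore expected to give 2.1 in this assay, with a plausible range from 1.6 to 2.6. The expected step is a number 0.38 log units higher from compound 3 to compound 4 (beyond the scatter).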

Compound 4, partition coefficient: 1.72
Estimate against measurement, compound 4: 0.38 log units above; the measured number falls inside the stated range.
By their numbers in this assay, from the lowest: compounds 1, 3 and 4 (each within the scatter of the next); then compound 2.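

In this assay, putting 3-(trifluoromethyl)phenyl in place of 2-methoxyphenyl on this aromatic carbon, next to the ring nitrogen, gives no change at the digits printed from compound 3 to compound 4 (within the scatter) and so leaves the read-out within the scatter, even though the entering group has 0 hydrogen-bond acceptors where the leaving group has 1. The comparison with the 4-ethylphenyl group gives a number 0.06 log units higher from compound 1 to compound 4 (within the scatter) and is also within the scatter, so three different aryl groups at this position, in compounds 1, 3 and 4, cannot be told apart on this read-out. Only the 4-acetylphenyl group stands apart, with a number 0.34 log units lower from compound 2 to compound 4 (beyond the scatter) adding a third step beyond the scatter and leaving compound 2 the highest of the four.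

Nothing measured here explains why the three aryl groups agree or why the acetyl-bearing one differs.

Each exchange shown changes both the substituent and its place on the phenyl ring, so the contribution of each remains unseparated. Also open, from the compounds shown here alone, is how a phenyl ring carrying an amine or a carboxylic acid would read at this position, and whether the step seen with the acetyl group would recur with another carbonyl group, such as an amide.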